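Sulfamoyl for methoxy on the core of compound 1

This account rests on a few compounds, and the source may have more. Where it says the series, first, only, none or still open, it means among the compounds named here.

Compound 1 `COc1ccc2c(O)c(C(=O)O)cnc2c1` stands highest of the three numbers measured in a functional assay on Ehrlich cells (Mus musculus) for inhibition (on this read-out lower numbers stand for stronger inhibition and higher numbers for weaker inhibition), where compound 1 gives 525000 nM. Compound 2 `O=C(O)c1cnc2cc(OCc3c(Cl)c(Cl)c(Cl)c(Cl)c3Cl)ccc2c1O` gives 42700 nM in this assay, and compound 3 `O=C(O)c1cnc2cc(OCc3ccc(Cl)c(Cl)c3)ccc2c1O` gives 15100 nM. For the measured compounds named here, the only step measured in one place is a 35-fold lower number from compound 1 to compound 3 (1.54 log units; beyond the scatter), brought about by 3,4-dichlorophenyl in place of hydrogen on a saturated chain carbon bound to an oxygen on an aromatic ring. Compound 4 `NS(=O)(=O)c1ccc2c(O)c(C(=O)O)cnc2c1` is not yet measured; it differs from compound 1 by sulfamoyl in place of methoxy on an aromatic carbon. Going by the values given here, no measured step bears on this exchange: the one large step known concerns a ring added to the chain on the ring oxygen, while the sulfamoyl enters on an aromatic carbon of the core itself, and both measured steps away from compound 1 run toward lower numbers only through chlorinated rings. For compound 4 no step beyond the scatter is therefore expected, and the estimate in this assay is 500000 nM. The expected range for compound 4 runs from 150000 nM to 1500000 nM. This amounts to an expected step of a 1.1-fold lower number from compound 1 to compound 4 (0.02 log units; within the scatter).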

Compound 4, half-maximal inhibitory concentration: 3390000 nM
Compound 4: the middle estimate sits 6.8-fold (0.83 log units) below what was measured; measured number outside the range, above it.
By their numbers in this assay, from the lowest: compound 3; then compound 2; then compound 1; then compound 4.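

In this assay the aromatic carbon that carries methoxy proves sensitive to an exchange made directly on the shared core, with sulfamoyl in place of methoxy giving a 6.5-fold higher number from compound 1 to compound 4 (0.81 log units; beyond the scatter) as a modest step. This step runs opposite to a 35-fold lower number from compound 1 to compound 3 (1.54 log units; beyond the scatter), so changes at this place can move the number in either direction, although the first keeps the ring oxygen and the sulfamoyl exchange removes it. Nothing available accounts for the size or direction of the new step.

The compounds shown do not separate the loss of the methoxy group from the entry of sulfamoyl. From the compounds shown here alone, whether an amine or a carboxylic acid on this aromatic carbon would fall nearer to compound 1 or to compound 4 remains open.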